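Swapping methoxy for trifluoromethyl on a weak gastric-cancer cell inhibitor

A few compounds are considered here, and "the series" means these few. Any claim that something is new, unique, unknown or untested is made for them only; others in the source may bear on it.

Measured compounds:
compound 1 `Cc1ccc(C(=O)Nc2ccc(CNC(=O)OCc3cccnc3)cc2)c(N2CCCC2)c1`, > 100000 nM
compound 2 `COc1ccc(N2CCCC2)c(C(=O)Nc2ccc(CNC(=O)OCc3cccnc3)cc2)c1`, 85700 nM
compound 3 `O=C(NCc1ccc(NC(=O)c2cccc(F)c2N2CCCC2)cc1)OCc1cccnc1`, > 100000 nM

Within the data shown here, in a functional assay on MGC-803 cells (Homo sapiens) for inhibition, read by MTT assay, with a stated time of 72 h (a higher number here means a weaker inhibitor, a lower number a stronger inhibitor), compound 2 gives 85700 nM, the only actual number among the three. For compound 1 the result is a limit, > 100000 nM. For compound 3 the result is likewise a limit, > 100000 nM. Among the measured compounds shown here, compound 2 therefore stands alone as the one compound with a measurable value, close to the limit of > 100000 nM in this assay, at which 2 of the 3 values shown sit.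

Compound 4 `O=C(NCc1ccc(NC(=O)c2cc(C(F)(F)F)ccc2N2CCCC2)cc1)OCc1cccnc1` differs from compound 2 in one place: trifluoromethyl in place of methoxy on an aromatic carbon. For the measured compounds named here, no measured step guides this change, so the step expected in this assay from compound 2 to compound 4 is a 1.1-fold higher number from compound 2 to compound 4 (0.02 log units; within the scatter), no larger than the scatter. Compound 4 is estimated at 90000 nM, between 30000 nM and 300000 nM.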

Compound 4, half-maximal inhibitory concentration: 42100 nM
Compound 4: the middle estimate sits 2.1-fold (0.33 log units) above what was measured; measured number inside the range.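

In this assay, trifluoromethyl in place of methoxy on the aromatic carbon para to the pyrrolidin-1-yl group gives a 2.0-fold lower number from compound 2 to compound 4 (0.31 log units; beyond the scatter), a modest gain. This position therefore accepts a group with more heavy atoms without a loss. Even so, both compounds remain weak, with readings not far from the top of what the test reports: the limit of > 100000 nM in this assay, at which 2 of the 4 values shown sit.

Going by these compounds, whether an amine, a nitrile or a carboxylic acid at this position would move the number further stays open. A single pair also cannot show what about trifluoromethyl lies behind the step.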